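The source may hold more compounds than are shown below. What is called first, only, known or untested is meant among the compounds shown, and "the series" means these compounds.

Compound 1 `N[C@H]1CC[C@H](Nc2c(C(=O)NCc3ccco3)nc(Br)c3cccnc23)CC1` was tested in a functional assay on HCT-116 cells (Homo sapiens) for cytotoxicity, read by MTT assay, with a stated time of 72 h; on this read-out lower numbers stand for stronger inhibition and higher numbers for weaker inhibition. In this assay compound 1 gives only a limit, > 10000 nM, and not a number (the limit of > 10000 nM in this assay, at which 1 of the 2 values shown sits). Compound 2 `O=C(NCc1ccc(F)cc1)c1nc(Br)c2cccnc2c1NCCCNc1c(C(=O)NCc2ccc(F)cc2)nc(Br)c2cccnc12` is a larger related compound built from two copies of the shared core. In this assay compound 2 likewise gives only a limit, > 20000 nM, and not a number (the limit of > 20000 nM in this assay, at which 1 of the 2 values shown sits). Compound 3 `N[C@H]1CC[C@H](Nc2c(C(=O)NCc3ccccc3)nc(Br)c3cccnc23)CC1` has not yet been measured. It differs from compound 1 in a single place: phenyl in place of furan-2-yl on a saturated chain carbon bound to an amide-type nitrogen. Within the data shown here, no step between two measured compounds is available to calibrate such a change, and compound 1 itself sits at a limit, so the step is expected to be no larger than the usual scatter and in no certain direction, a step that the limit leaves unreadable from compound 1 to compound 3. Compound 3 is therefore expected to give about 15000 nM, between 5000 nM and 50000 nM, and most probably to be reported once more only as a limit.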

Compound 3, half-maximal inhibitory concentration: 7000 nM
Estimate against measurement, compound 3: 2.1-fold (0.33 log units) above; measured number inside the range.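

Of the compounds shown, only compound 3 gives a number rather than a limit in this assay, so a benzyl group on the amide nitrogen is the one case here with a readable value. Placing phenyl where furan-2-yl stood, on a saturated chain carbon bound to an amide-type nitrogen, gives an at least 1.4-fold lower number from compound 1 to compound 3 (0.15 log units; that floor lies within the scatter). The real size of this step stays unknown because compound 1 is reported only as a limit: the limit of > 10000 nM in this assay, at which 1 of the 3 values shown sits.

Compound 2 differs from the other two compounds in more than one place, so it cannot be compared with them. As far as these compounds go, it remains open whether another ring at this place, such as thiophen-2-yl, or a longer chain, such as 2-phenylethyl in place of benzyl, would give a lower number than compound 3 does.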